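Benzamide series: sulfur-linked aryl group, compound 3 to compound 4

A few compounds are considered here, and "the series" means these few. Any claim that something is new, unique, unknown or untested is made for them only; others in the source may bear on it.

Measured so far in a functional assay on A-375 cells (Homo sapiens) for inhibition, read by CCK-8 assay, with a stated time of 72 h, tested at 8 uM; on this read-out higher numbers stand for more inhibition of growth at the one concentration tested and lower numbers for less inhibition of growth:
- compound 1, `Cc1ccc(SCc2ccc(/C=C/C(=O)Nc3ccccc3N)cc2)cc1`: 31.2%
- compound 2, `Nc1ccccc1NC(=O)c1ccc(CSc2ccc(C(F)(F)F)cn2)cc1`: 5.34%
- compound 3, `COc1ccc(SCc2ccc(C(=O)Nc3ccccc3N)cc2)cc1`: 81.8%

Compound 3 gives the highest of the three numbers in this assay. Compound 1 comes nearest, with a value lower by a margin beyond the scatter, and compound 2 sits furthest below, also beyond the scatter. No two of the measured compounds differ in only one place, so these gaps are read only as what the three values show, not as single steps.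

Compound 4, `Nc1ccccc1NC(=O)c1ccc(CSc2cccc(F)c2)cc1`, is the next compound to be measured in this assay. It differs from compound 3 as follows: 3-fluorophenyl in place of 4-methoxyphenyl on a sulfur. The sulfur attached to the saturated chain carbon is kept; only the aryl group on that sulfur changes.

Nothing in the measured set isolates this exchange, so the step is expected rather than known. Compound 4 is estimated at 55%, between 25% and 85%, which means an expected step of a number 26.8 percentage points lower from compound 3 to compound 4 (beyond the scatter), a loss beyond the scatter but leaving compound 4 still above compound 2.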

Compound 4, percent growth inhibition at one concentration: 76.3%
The estimate for compound 4 lay 21.3 percentage points below the measured number; the range from low to high includes it.
By their numbers in this assay, from the lowest: compound 2; then compound 1; then compounds 4 and 3 (each within the scatter of the next).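

In this assay, going by these compounds alone, the aryl group on the sulfur accepts the exchange of 4-methoxyphenyl for 3-fluorophenyl, with a number 5.5 percentage points lower from compound 3 to compound 4 (within the scatter) as the first single-place step. The oxygen of the 4-methoxyphenyl group, the one hydrogen-bond acceptor counted in the leaving group, is therefore not required on this aryl group to keep growth inhibition at this level at the single concentration tested. No measurement at hand gives a reason for this outcome.

The exchange alters both the substituent and its place on the ring, so 4-fluorophenyl and 3-methoxyphenyl would be needed to separate the two. Going by these compounds, whether an amine or a carboxylic acid on this aryl group would also hold the number remains open.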